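Furan-3-yl for trifluoromethylphenyl: the cytotoxicity outlook

The compounds below may be only part of what the source reports. "The series", "measured", "known", "first", "only" and "open" are said of these compounds alone.

For the measured compounds named here, compound 2 `O=C(NC(=S)N1CCc2c(OCCCCCOc3ccc(Cl)cc3)cccc21)c1ccc(C(F)(F)F)cc1` holds the only number in an ADME assay on Huh-7 cells (Homo sapiens) for cytotoxicity (on this read-out lower numbers stand for higher toxicity in this test and higher numbers for lower toxicity in this test), where compound 2 gives 32700 nM. Compound 1 `O=C(NC(=S)N1CCc2c(OCCCCCOc3ccc(Cl)cc3)cccc21)Oc1ccccc1` reaches only a limit of this assay, > 50000 nM. Going by the values given here, the single measured step at the same place is an at least 1.5-fold lower number from compound 1 to compound 2 (0.18 log units; that floor lies within the scatter), and its size is bounded because compound 1 sits at the limit of > 50000 nM in this assay, at which 1 of the 2 values shown sits. Compound 3 `O=C(NC(=S)N1CCc2c(OCCCCCOc3ccc(Cl)cc3)cccc21)c1ccoc1` carries furan-3-yl in place of 4-(trifluoromethyl)phenyl on a carbonyl carbon. Among the compounds with values here, as the one comparable step barely cleared its floor, no shift beyond the scatter is expected in this assay. Compound 3 is expected to give 40000 nM, between 15000 nM and 100000 nM. The step of a 1.2-fold higher number from compound 2 to compound 3 (0.09 log units; within the scatter) is therefore expected to be small.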

Compound 3, half-maximal cytotoxic concentration: 20100 nM
Compound 3: middle estimate off by 2.0-fold (0.30 log units), on the high side; measured number inside the range.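

In this assay, furan-3-yl on this carbonyl carbon gives a 1.6-fold lower number from compound 2 to compound 3 (0.21 log units; within the scatter), so a five-membered aromatic ring with a hetero atom and a six-membered carbon-only ring are not told apart here. Set against phenoxy, this place shows its first step that clears the scatter, an at least 2.4-fold lower number from compound 1 to compound 3 (0.39 log units; beyond the scatter). That size is only a floor, since compound 1 gives a limit and not a number: the limit of > 50000 nM in this assay, at which 1 of the 3 values shown sits.

The compounds shown leave open whether a saturated group such as cyclohexyl, or a basic one such as a piperidine, on this carbonyl carbon would read like the two aromatic groups. As far as these compounds go, how far phenoxy truly stands from them also stays open.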